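A few compounds are considered here, and "the series" means these few. Any claim that something is new, unique, unknown or untested is made for them only; others in the source may bear on it.

Working notes on the series. For the measured compounds named here, compound 2 `Cc1cn2c(-c3cn[nH]c3)cnc2c(Nc2cc(Cc3cnccn3)ns2)n1` is the only member with a number in an ADME assay on Caco-2 cells (Homo sapiens) for permeability, in the apical to basolateral direction; on this read-out higher numbers stand for higher permeability and lower numbers for lower permeability; compound 1 `Cc1cn2c(-c3cn[nH]c3)cnc2c(Nc2cc(Cn3cccc3)ns2)n1`, which carries the same core, shows in this assay "not determined" (no result reported), so compound 2 stands alone and no ordering among measured compounds can be drawn. In this assay compound 2 gives 43 nm/s.

Compound 3 `Cc1cn2c(-c3cn[nH]c3)cnc2c(Nc2cc(Cc3ccccn3)ns2)n1` differs from compound 2 in one place: pyridin-2-yl in place of pyrazin-2-yl on a saturated chain carbon bound to an aromatic carbon. Going by the values given here, no step between two measured compounds is available for this kind of exchange, so the size of the step must be guessed. For compound 3 a small to moderate rise in this assay is expected, of a size that may sit at the edge of the usual scatter, with an expected step from compound 2 of a 1.9-fold higher number from compound 2 to compound 3 (0.27 log units; within the scatter). The estimate for compound 3 in this assay is 80 nm/s, with a range from 35 nm/s to 200 nm/s.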

Compound 3, apparent permeability: 28 nm/s
For compound 3 the middle estimate is 2.9-fold (0.46 log units) above the measured one, and the stated range ends above it.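

In this assay, the exchange of pyrazin-2-yl for pyridin-2-yl on a saturated chain carbon bound to an aromatic carbon gives a 1.5-fold lower number from compound 2 to compound 3 (0.19 log units; within the scatter) and so does not separate the two compounds on this read-out. At this place, the ring can thus go from 2 hydrogen-bond acceptors to 1, with the heavy-atom count unchanged, without a step beyond the usual scatter. No measured property of either group is available to account for this result.

The compounds shown leave open whether an amine, a carboxylic acid or a longer chain at this place would give a step beyond the scatter. They also leave open whether the same exchange would give a comparable step on a different core.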